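From Pentyl to Hexyloxy: A Step Expected to Stay Small

This account rests on a few compounds, and the source may have more. Where it says the series, first, only, none or still open, it means among the compounds named here.

- Compound 1 `O=C1NCCN1c1ccc(S(=O)(=O)Nc2ccc(I)cc2)cc1` gives 650 nM
- Compound 2 `O=C1NCCN1c1ccc(S(=O)(=O)Nc2ccc(Cl)cc2)cc1` gives 220 nM
- Compound 3 `CCCCCc1ccc(NS(=O)(=O)c2ccc(N3CCNC3=O)cc2)cc1` gives 990 nM

These values come from a functional assay on HT-29 cells (Homo sapiens) for antiproliferative activity, read by sulforhodamine B assay, with a stated time of 48 h; a higher number here means a weaker inhibitor, a lower number a stronger inhibitor. Compound 3 sits with compound 1 at the upper end of the numbers, the gap being a 1.5-fold higher number from compound 1 to compound 3 (0.18 log units; within the scatter). Compound 2 stands apart, with a 4.5-fold higher number from compound 2 to compound 3 (0.65 log units; beyond the scatter).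

Compound 4 `CCCCCCOc1ccc(NS(=O)(=O)c2ccc(N3CCNC3=O)cc2)cc1` carries hexyloxy in place of pentyl on an aromatic carbon, para to a large group (hexyloxy in place of pentyl on an aromatic carbon). For the measured compounds named here, no measured step makes this exchange, so the evidence is indirect. At the same place, the three groups tested gave steps no larger than modest: a 3.0-fold lower number from compound 1 to compound 2 (0.47 log units; beyond the scatter) and the two already given. The pentyl chain of compound 3 shows 990 nM, and it is the closest measured match to hexyloxy. No step beyond the scatter is therefore expected, and the expected change is a 1.1-fold higher number from compound 3 to compound 4 (0.05 log units; within the scatter). For compound 4 the estimated value is 1100 nM, with an expected range of 350 nM to 3500 nM.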

Compound 4, half-maximal inhibitory concentration: > 1000 nM
Compound 4: only a limit was reported; the forecaster's own chance of this, stated with the estimate: 3%; the middle value lies beyond the limit too.
By their numbers in this assay, from the lowest: compound 2; then compounds 1 and 3 (each within the scatter of the next). At a limit, above all of these: compound 4.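

The result for compound 4 is a limit and not a number: the limit of > 1000 nM in this assay, at which 1 of the 4 values shown sits. The exchange of pentyl for hexyloxy at this place gives a number no lower from compound 3 to compound 4 (the limit leaves the size open). Even so, the exchange of chloro for hexyloxy on this aromatic carbon gives an at least 4.5-fold higher number from compound 2 to compound 4 (0.65 log units; beyond the scatter), so this oxygen-bearing chain does not reach the low number seen with chloro. The exchange of iodo for hexyloxy gives an at least 1.5-fold higher number from compound 1 to compound 4 (0.18 log units; that floor lies within the scatter), and with a floor of that size, this comparison does not separate hexyloxy from iodo.

The compounds shown leave open how much of the result belongs to the oxygen and how much to the longer chain, since no hexyl or pentyloxy group appears among them. They also leave open how a short methoxy group, an amine or a carboxylic acid would behave at this place.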